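The compounds below may be only part of what the source reports. "The series", "measured", "known", "first", "only" and "open" are said of these compounds alone.

Series notes on three compounds measured in a functional assay on DU-145 cells (Homo sapiens) for inhibition, read by trypan blue exclusion, with a stated time of 96 h; on this read-out higher numbers stand for weaker inhibition of growth and lower numbers for stronger inhibition of growth. Compound 2 `CCOc1ccc(/C=C(\C(=O)c2ccc(Cl)cc2)S(=O)(=O)c2ccc(C)cc2)cc1OC` gives 1000 nM, the lowest of the three numbers. Compound 1 `CCOc1ccc(/C=C(\C(=O)c2ccc(Cl)cc2)S(=O)(=O)Cc2ccc(C)cc2)cc1OC` gives 10000 nM; the change of 4-methylphenyl in place of 4-methylbenzyl on a sulfonyl sulfur gave a 10-fold lower number from compound 1 to compound 2 (1.00 log units; beyond the scatter). Among the measured compounds shown here, compound 3 `Cc1ccc(S/C(=C/c2ccc(Cl)c(Cl)c2)C(=O)c2ccc(Br)cc2)cc1` gives 50000 nM, the value furthest from compound 2; the two differ in several places, so no single step connects them.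

Compound 4 `CCOc1ccc(/C=C(/Sc2ccccc2Cl)C(=O)c2ccc(Cl)cc2)cc1OC` is unmeasured. It differs from compound 2 in one place: (2-chlorophenyl)sulfanyl in place of (4-methylphenyl)sulfonyl on a double-bonded chain carbon bound to a carbonyl carbon and a double-bonded chain carbon. For the measured compounds named here, no measured step bears directly on this change; the only measured step, from compound 1 to compound 2, alters the group on the sulfonyl sulfur and keeps the sulfonyl itself. Going by the values given here, the sole sulfanyl compound measured is compound 3, whose value of 50000 nM is the highest of the three, though it carries other differences too. Compound 4 is therefore expected to give a higher number in this assay, a step of roughly an 8.0-fold higher number from compound 2 to compound 4 (0.90 log units; beyond the scatter), held loosely given the thin evidence. Compound 4 is estimated at 8000 nM, with a range from 1500 nM to 40000 nM.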

Compound 4, concentration for 50% growth inhibition: 50000 nM
Compound 4: the middle estimate sits 6.3-fold (0.80 log units) below what was measured, and the stated range ends below it.
By their numbers in this assay, from the lowest: compound 2; then compound 1; then compounds 3 and 4 (each within the scatter of the next).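

In this assay the place on a double-bonded chain carbon bound to a carbonyl carbon and a double-bonded chain carbon now has a direct reading, whereas the earlier step changed only the group on the sulfonyl sulfur. Exchanging the whole group there for (2-chlorophenyl)sulfanyl gives a 50-fold higher number from compound 2 to compound 4 (1.70 log units; beyond the scatter), and against the other sulfonyl compound it gives a 5.0-fold higher number from compound 1 to compound 4 (0.70 log units; beyond the scatter), so among these three compounds both sulfonyl compounds carry the lower numbers, with none going against this. Nothing measured here explains why this exchange weakens growth inhibition.

The change alters the sulfur link and the ring substituent together, so the shares of the sulfanyl link and of the 2-chloro substituent in these steps remain unresolved. A (2-chlorophenyl)sulfonyl group at this place would separate the two, and a sulfinyl link would show how the number behaves between the sulfanyl and sulfonyl forms.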